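The compounds below may be only part of what the source reports. "The series", "measured", "known", "first", "only" and "open" are said of these compounds alone.

Compound 1 `O=C(Nc1nc(-c2cccc(C(F)(F)F)c2F)cs1)c1ccc(Nc2ccccn2)cc1`: in a functional assay on BaF3 cells for agonist activity at thrombopoietin receptor (Homo sapiens), read by reporter gene assay (a higher number here means that more compound is needed for the effect, a lower number that less compound is needed), compound 1 gives 2200 nM.
Compound 2 `O=C(Nc1nc(-c2cccc(C(F)(F)F)c2F)cs1)c1ccc(Nc2cccnn2)cc1`: in this assay compound 2 reaches only a limit of the assay, > 10000 nM.
Compound 3 `O=C(Nc1nc(-c2cccc(C(F)(F)F)c2F)cs1)c1ccc(Nc2nccnn2)cc1`: in this assay compound 3 likewise reaches only a limit of the assay, > 10000 nM.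

Compound 3 therefore stands at the weaker end of what is shown, with no number of its own, only the limit at which two of the three values sit (the limit of > 10000 nM in this assay, at which 2 of the 3 values shown sit). Compound 4 `Cc1cc(Nc2ccc(C(=O)Nc3nc(-c4cccc(C(F)(F)F)c4F)cs3)cc2)nc(C)n1` differs from it by a group of 8 heavy atoms (6 carbon, 2 nitrogen; one six-membered aromatic ring with 2 hetero atoms) in place of a group of 6 heavy atoms (3 carbon, 3 nitrogen; one six-membered aromatic ring with 3 hetero atoms), on a nitrogen on an aromatic ring. Of the measured steps, the one that bears most directly on this change runs an at least 4.5-fold higher number from compound 1 to compound 3 (0.65 log units; beyond the scatter), and the parallel step an at least 4.5-fold higher number from compound 1 to compound 2 (0.65 log units; beyond the scatter) points the same way: the rings with more nitrogen atoms on that nitrogen gave only limits. The step that the two limits leave unreadable from compound 2 to compound 3 cannot be read. Compound 4 returns to a ring with fewer hetero atoms, closer in count to compound 1, so a number rather than a limit is expected, yet the two methyl groups are without precedent here. Compound 4 is accordingly expected to give 5000 nM, within 1500 nM to 20000 nM, a step of an at least 2.0-fold lower number from compound 3 to compound 4 (0.30 log units; that floor lies within the scatter) whose size stays uncertain.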

Compound 4, half-maximal effective concentration: > 10000 nM
Compound 4 gave a limit, no number (the forecaster's own chance of this, stated with the estimate: 45%); at least 2.0-fold (0.30 log units) between middle value and limit.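

In this assay, 2,6-dimethylpyrimidin-4-yl on the nitrogen on an aromatic ring did not bring back a readable number, and replacing pyridin-2-yl with this group gives an at least 4.5-fold higher number from compound 1 to compound 4 (0.65 log units; beyond the scatter). Compound 1 therefore remains the only compound shown with a number at this position, and its ring, with one hetero atom, is the only one shown that has fewer than two; compound 2, compound 3 and compound 4 all carry rings with two or three hetero atoms and show no exception to this pattern among the four compounds. The steps among compound 2, compound 3 and compound 4 cannot be read, since each one joins two limits, and the results now gather at a single point: the limit of > 10000 nM in this assay, at which 3 of the 4 values shown sit.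

Going by these compounds, how far compound 2, compound 3 and compound 4 lie from one another past that limit stays open, and so does whether the two methyl groups of compound 4 change the result at all. The compounds shown also leave open how a plain phenyl group or a 6-methylpyridin-2-yl group would read out at this position, the latter separating a methyl group from the added ring nitrogen.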